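Pyridin-3-yl in place of thiophen-2-yl

The compounds below may be only part of what the source reports. "The series", "measured", "known", "first", "only" and "open" are said of these compounds alone.

Values measured in a functional assay on CWR22R cells (Homo sapiens) for antiproliferative activity, read by CCK-8 assay, with a stated time of 6 days (on this read-out higher numbers stand for weaker inhibition and lower numbers for stronger inhibition), are as follows.
Compound 1 `CCN(c1ccc(C#N)c(Cl)c1)c1cc(-n2cnc3ccccc32)ccc1C` gives 3040 nM
Compound 2 `Cn1nccc1-c1cccc2c1CCCN2c1ccc(C#N)c(C(F)(F)F)c1` gives 10400 nM
Compound 3 `CCN(c1ccc(C#N)c(Cl)c1)c1cc(-c2cccs2)ccc1C` gives 22000 nM

Compound 3 has the highest number of the three, while compound 2 and compound 1 both lie lower. Compound 4 `CCN(c1ccc(C#N)c(Cl)c1)c1cc(-c2cccnc2)ccc1C` carries pyridin-3-yl in place of thiophen-2-yl on an aromatic carbon. Going by the values given here, only one measured step bears on this place, the modest 7.2-fold higher number from compound 1 to compound 3 (0.86 log units; beyond the scatter) beyond the scatter, and no measured compound other than compound 4 carries pyridin-3-yl. Compound 1 thus shows, through a 7.2-fold higher number from compound 1 to compound 3 (0.86 log units; beyond the scatter) in the reverse direction, that a lower number is reachable here. A smaller move towards a lower number is therefore expected in this assay for the new ring. The expected change is a 2.8-fold lower number from compound 3 to compound 4 (0.44 log units; beyond the scatter) on this estimate. Compound 4 is estimated at 8000 nM with 2500 nM to 25000 nM as its expected range.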

Compound 4, half-maximal inhibitory concentration: 2000 nM
Estimate against measurement, compound 4: 4.0-fold (0.60 log units) above; measured number outside the range, below it.
By their numbers in this assay, from the lowest: compounds 4 and 1 (each within the scatter of the next); then compound 2; then compound 3.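

In this assay the position proves highly sensitive to the ring it carries, with pyridin-3-yl in place of thiophen-2-yl giving an 11-fold lower number from compound 3 to compound 4 (1.04 log units; beyond the scatter) and showing that a six-membered aromatic ring with a nitrogen can serve here. Pyridin-3-yl and 1H-benzimidazol-1-yl cannot be told apart, since replacing the latter gives a 1.5-fold lower number from compound 1 to compound 4 (0.18 log units; within the scatter) and leaves thiophen-2-yl alone among the three with the higher number. Nothing available explains this difference between the rings. Still open, going by these compounds, is whether pyridin-2-yl or pyridin-4-yl would match pyridin-3-yl, and whether an amine or a carboxylic acid on that ring would retain this level.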